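A few compounds are considered here, and "the series" means these few. Any claim that something is new, unique, unknown or untested is made for them only; others in the source may bear on it.

Measured compounds:
compound 2 `Clc1nss/c1=N\c1cccc(Br)c1` — in a functional assay on DU-145 cells (Homo sapiens) for cytotoxicity, read by resazurin assay, with a stated time of 72 h (a lower number here means a stronger inhibitor, a higher number a weaker inhibitor), compound 2 gives 27000 nM
compound 1 `FC(F)(F)Oc1ccc(/N=c2\ssnc2Cl)cc1Br` — in this assay compound 1 gives 52000 nM

Going by the values given here, compound 2 stands at one end of these two numbers; its only neighbour is compound 1, and the step of a 1.9-fold lower number from compound 1 to compound 2 (0.28 log units; within the scatter) keeps the pair inside the scatter, so the two numbers are not distinguished. Among the compounds with values here, that single step concerns hydrogen in place of trifluoromethoxy on an aromatic carbon and is the only comparison available.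

Compound 3 `N#Cc1c(Br)cccc1/N=c1\ssnc1Cl` differs from compound 2 by cyano in place of hydrogen on an aromatic carbon. Within the data shown here, no measured step touches a cyano group, so nothing speaks directly for or against this change. Among the measured compounds shown here, with the one measured step within the scatter, no step beyond the scatter is expected in this assay from compound 2 to compound 3, and the estimated step is a 1.1-fold lower number from compound 2 to compound 3 (0.03 log units; within the scatter). Compound 3 is therefore expected to give about 25000 nM, with a range from 8000 nM to 80000 nM.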

Compound 3, half-maximal inhibitory concentration: 42000 nM
For compound 3 the middle estimate is 1.7-fold (0.23 log units) below the measured one; low and high end bracket the measured number.
By their numbers in this assay, from the lowest: compounds 2, 3 and 1 (each within the scatter of the next).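

In this assay, cyano in place of hydrogen on the aromatic carbon ortho to a bromo group and ortho to a group of 7 heavy atoms gives a 1.6-fold higher number from compound 2 to compound 3 (0.19 log units; within the scatter). This carbon can therefore carry cyano, even with both flanking places occupied, without a change that can be told from the scatter. With the earlier trifluoromethoxy step, two different substituents on this aromatic ring now leave the number within the scatter, and nothing available explains the size of this step.

Open, on these data alone, is whether an amine or a carboxylic acid on this same aromatic carbon would take the number beyond the scatter. Also open, as far as these compounds go, is whether a methyl group in place of the bromo group would do so.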